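The source may report more compounds than this note shows. Statements on the series, on what has been measured and on what is new or still open speak of the compounds shown alone.

Of the compounds shown here, two built on the same core have so far been tested in a functional assay on HT-29 cells (Homo sapiens) for inhibition, read by sulforhodamine B assay, with a stated time of 48 h; a higher number here means a weaker inhibitor of growth, a lower number a stronger inhibitor of growth. Compound 1, `CC1=CC[C@H](C(C)(C)NC(=S)N/N=C/c2ccccc2)CC1`, gives 22200 nM. Compound 2, `CC1=CC[C@H](C(C)(C)NC(=S)N/N=C/c2ccccc2O)CC1`, gives 16600 nM. For the measured compounds named here, the single step between them, a 1.3-fold lower number from compound 1 to compound 2 (0.13 log units; within the scatter), is too small to count as a real difference. Compound 2 therefore holds the lower of the two numbers, but its gap to compound 1 lies within the scatter, so the two cannot be told apart on the evidence at hand.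

Compound 3, `CC1=CC[C@H](C(C)(C)NC(=S)N/N=C/c2ccc(F)cc2)CC1`, has not yet been measured. It differs from compound 2 in one place: 4-fluorophenyl in place of 2-hydroxyphenyl on a carbon with a double bond to nitrogen. Going by the values given here, no measured step swaps one substituted phenyl for another, so the only guide is that the one change already seen on this ring, adding hydroxy, moved the number by no more than the scatter. On that basis compound 3 is expected to land close to compound 2, with a 1.2-fold higher number from compound 2 to compound 3 (0.08 log units; within the scatter) as the estimated step and no real change beyond the scatter. The estimate for compound 3 in this assay is 20000 nM, expected to fall between 8000 nM and 50000 nM.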

Compound 3, concentration for total growth inhibition: > 100000 nM
Compound 3 was reported as a limit (the forecaster's own chance of this, stated with the estimate: 5%); at least 5.0-fold (0.69 log units) between middle value and limit.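

For the compounds shown here, until now, the only change seen on this aromatic ring was hydroxy in place of hydrogen, and in this assay that step stayed within the scatter, so the ring could have seemed to accept a small group without consequence. Compound 3 shows that this is not always so: fluoro in place of hydrogen on an aromatic carbon gives an at least 4.5-fold higher number from compound 1 to compound 3 (0.65 log units; beyond the scatter), and 4-fluorophenyl in place of 2-hydroxyphenyl on a carbon with a double bond to nitrogen gives an at least 6.0-fold higher number from compound 2 to compound 3 (0.77 log units; beyond the scatter), so one small group on this ring can carry the compound beyond the scatter toward weaker growth inhibition. The value of compound 3 is a limit and not a number, so both steps give only a smallest size: the limit of > 100000 nM in this assay, at which 1 of the 3 values shown sits.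

The compounds shown cannot tell whether this weakening belongs to fluoro alone or would also come with other groups on the ring, such as chloro, methoxy, an amine or a carboxylic acid. Nor can they tell how far the number would move, since the true value of compound 3 is not known.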